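The source may report more compounds than this note shows. Statements on the series, on what has been measured and on what is new or still open speak of the compounds shown alone.

Working notes on the series. In a functional assay on NCI-H460 cells (Homo sapiens) for cytotoxicity, read by MTT assay, with a stated time of 96 h (on this read-out lower numbers stand for stronger inhibition and higher numbers for weaker inhibition), compound 1 (`COc1ncc(-c2cc(OC3CCN(C)CC3)c3nc(N)nc(C)c3c2)cc1NS(=O)(=O)c1ccc(F)cc1F`) gives 660 nM, compound 2 (`CNc1nc(C)c2cc(-c3cnc(OC)c(NS(=O)(=O)c4ccc(F)cc4F)c3)cc(OC3CCOCC3)c2n1`) gives 59 nM and compound 3 (`CNc1nc(C)c2cc(-c3cnc(OC)c(NS(=O)(=O)c4ccc(F)cc4F)c3)cc(OCC3CCOC3)c2n1`) gives 310 nM, the middle of the three numbers. Next is compound 4 (`CNc1nc(C)c2cc(-c3cnc(OC)c(NS(=O)(=O)c4ccc(F)cc4F)c3)cc(OC3CCCCC3)c2n1`), with this difference: cyclohexyl in place of (oxolan-3-yl)methyl on an oxygen on an aromatic ring. In words, cyclohexyl stands in place of (oxolan-3-yl)methyl on an oxygen on an aromatic ring. Among the measured compounds shown here, the one measured step at this oxygen is a 5.3-fold higher number from compound 2 to compound 3 (0.72 log units; beyond the scatter), and it brought in the group that now leaves. Cyclohexyl resembles the oxan-4-yl of compound 2 more closely, so most of that modest step is expected to reverse in this assay. The expected change, toward a lower number, is a 3.1-fold lower number from compound 3 to compound 4 (0.49 log units; beyond the scatter). For compound 4 the estimate is 100 nM, with an expected range of 35 nM to 300 nM.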

Compound 4, half-maximal inhibitory concentration: 1700 nM
Compound 4: the middle estimate sits 17-fold (1.23 log units) below what was measured; measured number outside the range, above it.
By their numbers in this assay, from the lowest: compound 2; then compound 3; then compound 1; then compound 4.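

Across compounds 2, 3 and 4, which differ only on this oxygen on an aromatic ring, the two groups carrying a ring oxygen give lower numbers in this assay than cyclohexyl, which carries none. Removing that oxygen gives a 5.5-fold higher number from compound 3 to compound 4 (0.74 log units; beyond the scatter) and, from the better-placed group, a 29-fold higher number from compound 2 to compound 4 (1.46 log units; beyond the scatter), a larger step than a 5.3-fold higher number from compound 2 to compound 3 (0.72 log units; beyond the scatter). No available evidence accounts for this result. Still open, from the compounds shown here alone, is whether an open-chain ether such as 2-methoxyethyl, or a hydroxyl on the cyclohexyl ring, would give a number nearer that of compound 2.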